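The source may report more compounds than this note shows. Statements on the series, on what has been measured and on what is new or still open speak of the compounds shown alone.

Measured so far in a functional assay on B16 cells (Mus musculus) for cytotoxicity, read by MTT assay, with a stated time of 48 h; a lower number here means a stronger inhibitor, a higher number a weaker inhibitor:

Compound 1 `COc1ccc(C(O)c2cn(CCCO)nn2)cc1`: > 100000 nM
Compound 2 `COc1ccc(C(O)c2cn(C[C@H]3COC(C)(C)O3)nn2)cc1`: > 100000 nM
Compound 3 `OCCCn1cc(-c2ccc(C(F)(F)F)cc2)nn1`: > 100000 nM

In this assay compound 1 gives > 100000 nM, which is a limit of the assay rather than a number. Compound 2 gives > 100000 nM, also a limit. Compound 3 gives > 100000 nM, again a limit. (the limit of > 100000 nM in this assay, at which 3 of the 3 values shown sit). The change from compound 1 to compound 2 is 2,2-dimethyl-1,3-dioxolan-4-yl in place of 2-hydroxyethyl on a saturated chain carbon bound to an aromatic nitrogen; the two limits leave a step that the two limits leave unreadable from compound 1 to compound 2 unreadable, so no size can be given for it. Compound 4 `CC1(C)OC[C@H](Cn2cc(-c3ccc(C(F)(F)F)cc3)nn2)O1` has not yet been measured. It differs from compound 3 by 2,2-dimethyl-1,3-dioxolan-4-yl in place of 2-hydroxyethyl on a saturated chain carbon bound to an aromatic nitrogen, the same change as that from compound 1 to compound 2, made at the same place. How the core of compound 3 differs from the core of compound 1 is not broken down here.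

Among the compounds with values here, compound 3 sits at the limit, and the one earlier instance of the change, from compound 1 to compound 2, began and ended at the limit as well. On that basis compound 4 is expected to show a step that the limit leaves unreadable from compound 3 to compound 4, and its estimate is 150000 nM, with a likely range from 40000 nM to 600000 nM; most probably the assay will again report only a limit.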

Compound 4, half-maximal inhibitory concentration: > 100000 nM
Compound 4 was reported as a limit (the forecaster's own chance of this, stated with the estimate: 85%); the middle value lies beyond the limit too.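

Compound 3 and compound 4 both sit at a limit of this assay, so no step can be read between them, and the change adds no size to what was seen from compound 1 to compound 2: the limit of > 100000 nM in this assay, at which 4 of the 4 values shown sit.

The compounds shown leave open whether 2,2-dimethyl-1,3-dioxolan-4-yl in place of 2-hydroxyethyl alters the read-out at all, and how far any of the four lies beyond the limit.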